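Dropping an acetyl from the side-chain ester of compound 1

The compounds below may be only part of what the source reports. "The series", "measured", "known", "first", "only" and "open" are said of these compounds alone.

Within the data shown here, the shared core carries a short ester or ether on the oxygen of the saturated carbon, and the three measured members sit close together. Compound 1, `CC(=O)OCCC(=O)O[C@H](CC=C(C)C)C1=CC(=O)c2c(O)ccc(O)c2C1=O`, gives 15700 nM in a functional assay on DU-145 cells (Homo sapiens) for cytotoxicity, read by MTT assay (a lower number here means a stronger inhibitor, a higher number a weaker inhibitor), the second highest of the three numbers. Compound 2, `CC(=O)OCCO[C@H](CC=C(C)C)C1=CC(=O)c2c(O)ccc(O)c2C1=O`, gives 15500 nM, and compound 3, `CC[C@](C)(O)CC(=O)O[C@H](CC=C(C)C)C1=CC(=O)c2c(O)ccc(O)c2C1=O`, gives 20500 nM. The steps of a 1.0-fold lower number from compound 1 to compound 2 (0.01 log units; within the scatter) and a 1.3-fold higher number from compound 1 to compound 3 (0.12 log units; within the scatter) both stay within the scatter, as does a 1.3-fold higher number from compound 2 to compound 3 (0.12 log units; within the scatter).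

Compound 4, `CC(C)=CC[C@@H](OC(=O)CCO)C1=CC(=O)c2c(O)ccc(O)c2C1=O`, differs from compound 1 by hydrogen in place of acetyl on an oxygen on a saturated carbon. The most relevant step is the exchange of an ester for a free hydroxy group between compound 1 and compound 3, which was a 1.3-fold higher number from compound 1 to compound 3 (0.12 log units; within the scatter); the change from a carbonyl-bearing to a plain chain oxygen, a 1.0-fold lower number from compound 1 to compound 2 (0.01 log units; within the scatter), likewise moved nothing beyond the scatter. Removal of the acetyl is therefore expected to leave the number close to that of compound 1, with a step of a 1.0-fold higher number from compound 1 to compound 4 (0.01 log units; within the scatter) expected, and compound 4 is estimated at 16000 nM, within a range from 8000 nM to 35000 nM.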

Compound 4, half-maximal inhibitory concentration: 55300 nM
For compound 4 the middle estimate is 3.5-fold (0.54 log units) below the measured one; the whole stated range lies below it.
By their numbers in this assay, from the lowest: compounds 2, 1 and 3 (each within the scatter of the next); then compound 4.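

Among these compounds, removing the acetyl shows that this oxygen on a saturated carbon is not as tolerant as the earlier compounds suggested: hydrogen in place of acetyl gives the first change in this assay beyond the scatter (a 3.5-fold higher number from compound 1 to compound 4 (0.55 log units; beyond the scatter)). Compound 4 also stands apart from the other two compounds (a 3.6-fold higher number from compound 2 to compound 4 (0.55 log units; beyond the scatter); a 2.7-fold higher number from compound 3 to compound 4 (0.43 log units; beyond the scatter)), making it the weakest of the four, although compound 3 also carries a free hydroxy group, within its 1-hydroxy-1-methylpropyl. Nothing available accounts for this loss.

The compounds shown leave open whether a methoxy group or an amine in place of the hydroxy would keep the number of compound 4 or return it towards that of compound 1. They also leave open whether a longer acyl chain such as propionyl would match the acetyl.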